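Cytotoxicity Step from Compound 3 to Compound 4

The source may report more compounds than this note shows. Statements on the series, on what has been measured and on what is new or still open speak of the compounds shown alone.

Measured compounds:
Compound 1 `Cc1cc(/C=C2\SC(=S)N(Cc3ccc(C(F)(F)F)cc3)C2=O)c(C)n1-c1ccc(O)c(C(=O)O)c1` gives 45900 nM in an ADME assay on MT2 cells (Homo sapiens) for cytotoxicity, read by XTT assay, with a stated time of 4 days; on this read-out higher numbers stand for lower toxicity in this test and lower numbers for higher toxicity in this test.
Compound 2 `Cc1cc(/C=C2\SC(=S)N(Cc3ccc(C(=O)O)cc3)C2=O)c(C)n1-c1ccc(O)c(C(=O)O)c1` gives 105000 nM in this assay.
Compound 3 `Cc1cc(/C=C2\SC(=S)N(Cc3ccc(C(C)(C)C)cc3)C2=O)c(C)n1-c1ccc(O)c(C(=O)O)c1` gives 55200 nM in this assay.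

Compound 3 sits second highest of the three numbers. Its nearest neighbour is compound 1, with a 1.2-fold higher number from compound 1 to compound 3 (0.08 log units; within the scatter), and its furthest is compound 2, with a 1.9-fold lower number from compound 2 to compound 3 (0.28 log units; within the scatter); both of these gaps lie within the usual scatter.

Compound 4 `COC(=O)c1cccc(CN2C(=O)/C(=C/c3cc(C)n(-c4ccc(O)c(C(=O)O)c4)c3C)SC2=S)c1` differs from compound 3 in one place: 3-(methoxycarbonyl)phenyl in place of 4-(tert-butyl)phenyl on a saturated chain carbon bound to an amide-type nitrogen in a ring.

For the measured compounds named here, two steps bear on this change. The step of a 1.9-fold lower number from compound 2 to compound 3 (0.28 log units; within the scatter) shows that exchanging carboxy for tert-butyl on the benzyl ring moved the number only within the scatter, and a 2.3-fold higher number from compound 1 to compound 2 (0.36 log units; beyond the scatter) shows a modest rise when carboxy entered. An ester group enters here rather than a carboxy, so compound 4 is expected to give a small upward step, a 1.2-fold higher number from compound 3 to compound 4 (0.07 log units; within the scatter), probably within the scatter. The estimate for compound 4 in this assay is 65000 nM, with a range from 30000 nM to 140000 nM.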

Compound 4, half-maximal cytotoxic concentration: 38500 nM
Compound 4: the middle estimate sits 1.7-fold (0.23 log units) above what was measured; measured number inside the range.
By their numbers in this assay, from the lowest: compounds 4, 1, 3 and 2 (each within the scatter of the next, the first and the last beyond it).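

In this assay, 3-(methoxycarbonyl)phenyl brings hydrogen-bond acceptors that 4-(tert-butyl)phenyl lacks, yet this exchange gives a 1.4-fold lower number from compound 3 to compound 4 (0.16 log units; within the scatter), and the exchange with 4-(trifluoromethyl)phenyl gives a 1.2-fold lower number from compound 1 to compound 4 (0.08 log units; within the scatter). Exchanging 4-carboxyphenyl for the same ester-bearing group gives a 2.7-fold lower number from compound 2 to compound 4 (0.44 log units; beyond the scatter), so at this position the ester does not give the same number as the acid, although compound 3 stays within the scatter of both. None of the data shown explain why these numbers fall as they do.

Compound 2 and compound 4 differ both in the group on the ring and in where it sits, so the compounds shown leave open which of the two changes matters. They also leave open how an amine or a longer chain on this benzyl ring would read in this assay.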